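Acetylated diester series: from alkynyl esters to an alkynyl amide

This account rests on a few compounds, and the source may have more. Where it says the series, first, only, none or still open, it means among the compounds named here.

Measured so far:
Compound 1 `CC(=O)Oc1ccc(/C=C/C(=O)O)cc1OC(C)=O` in an assay on isolated protein for inhibition of Polyunsaturated fatty acid 5-lipoxygenase (Homo sapiens), read by HPLC, with a stated time of 15 min (a higher number here means a weaker inhibitor, a lower number a stronger inhibitor), gives > 10000 nM, which is a limit of the assay.
Compound 2 `C#CCCCCOC(=O)/C=C/c1ccc(OC(C)=O)c(OC(C)=O)c1` in this assay gives > 10000 nM, a limit.
Compound 3 `C#CCCCCCOC(=O)/C=C/c1ccc(OC(C)=O)c(OC(C)=O)c1` in this assay gives > 10000 nM, a limit.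

For the measured compounds named here, compound 3 therefore stands only at a limit, and the two other values shown are limits as well; no compound in the set has a number. Because the limit of > 10000 nM in this assay, at which 3 of the 3 values shown sit, the three steps among the measured compounds cannot be sized: a step that the two limits leave unreadable from compound 1 to compound 2, a step that the two limits leave unreadable from compound 1 to compound 3 and a step that the two limits leave unreadable from compound 2 to compound 3.

Compound 4 `C#CCCNC(=O)/C=C/c1ccc(OC(C)=O)c(OC(C)=O)c1` differs from compound 3 by a group of 5 heavy atoms (4 carbon, 1 nitrogen; no ring) in place of a group of 8 heavy atoms (7 carbon, 1 oxygen; no ring), on a carbonyl carbon; in words, a group of 5 heavy atoms (4 carbon, 1 nitrogen; no ring) in place of a group of 8 heavy atoms (7 carbon, 1 oxygen; no ring), on a carbonyl carbon whose other neighbour is a double-bonded chain carbon, with one hydrogen-bond donor entering and one acceptor leaving. The chain-shortening step and the two ester-forming steps bear on it, but all three are unreadable, so no size or direction can be drawn from them. On what is shown, compound 4 is expected to sit near the same limit. The estimate for compound 4 in this assay is 20000 nM, with a range from 3000 nM to 100000 nM. The step that the limit leaves unreadable from compound 3 to compound 4 is accordingly expected to be small and most likely not resolvable.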

Compound 4, half-maximal inhibitory concentration: > 10000 nM
Compound 4 ended at the assay's limit; the forecaster's own chance of this, stated with the estimate: 80%; the middle value is on the limit's open side.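

Compound 4 adds no readable step to compound 1, compound 2 or compound 3, because all four compounds stand at the same limit of the assay: the limit of > 10000 nM in this assay, at which 4 of the 4 values shown sit.

The compounds shown leave open how strongly, if at all, any of them inhibits the enzyme, and so whether exchanging the alkynyl ester for the alkynyl amide changes inhibition in either direction.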